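Halogen change on the pendant phenyl of compound 2

The source may report more compounds than this note shows. Statements on the series, on what has been measured and on what is new or still open speak of the compounds shown alone.

Compound 2 `O=C1COc2ccc(-c3[nH]c(-c4ccc(F)cc4)nc3-c3ccccc3)cc2N1` gives 1.1% in a functional assay on MV4-11 cells (Homo sapiens) for cytotoxicity, read by colorimetric assay and MTT assay, with a stated time of 3 days, tested at 20 uM (a higher number here means a weaker effect of the compound at the concentration tested, a lower number a stronger effect), the lowest of the two numbers shown, with compound 1 `COc1ccc(-c2nc(-c3ccccc3)c(-c3ccc4c(c3)NC(=O)CO4)[nH]2)cc1` at 1.2% sitting nearest. Within the data shown here, the one measured step, a number 0.1 percentage points lower from compound 1 to compound 2 (within the scatter), is the only guide here. Compound 3 `O=C1COc2ccc(-c3[nH]c(-c4ccc(Cl)cc4Cl)nc3-c3ccccc3)cc2N1` is compound 2 with 2,4-dichlorophenyl in place of 4-fluorophenyl on an aromatic carbon. Since that earlier swap on the same phenyl moved nothing beyond the scatter, compound 3 is expected to show a step of a number 0.9 percentage points higher from compound 2 to compound 3 (within the scatter), that is, no change beyond the scatter in this assay. For compound 3 the estimate in this assay is 2%, within a range from 0% to 15%.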

Compound 3, a percentage reported as activity, at one concentration (the size of the read-out at that concentration, not a potency): 41.1%
Beside the measured number, compound 3's estimate is 39.1 percentage points below it; measured number above the stated range.
By their numbers in this assay, from the lowest: compounds 2 and 1 (each within the scatter of the next); then compound 3.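

In this assay, this position on the ring between two ring nitrogen atoms proves sensitive to its aryl group, with a number 40 percentage points higher from compound 2 to compound 3 (beyond the scatter) and a number 39.9 percentage points higher from compound 1 to compound 3 (beyond the scatter). The swap between 4-methoxyphenyl and 4-fluorophenyl had not shown this, and 2,4-dichlorophenyl is the first group here to weaken the effect clearly. No available evidence accounts for this loss. The compounds shown leave open whether a phenyl carrying a single chlorine would behave like 2,4-dichlorophenyl or like 4-fluorophenyl. As far as these compounds go, how a phenyl bearing an amine or a carboxylic acid would read at this position also remains open.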